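From a Benzofuran to a Thiophene on a Nucleoside Core

The compounds below may be only part of what the source reports. "The series", "measured", "known", "first", "only" and "open" are said of these compounds alone.

The compounds here share one core that carries a 3,4-dihydroxy-5-(hydroxymethyl)oxolan-2-yl group, and they differ in what sits on one aromatic carbon of that core. Compound 1 `Cc1ncnc2c1c(-c1cc3ccccc3o1)cn2[C@@H]1O[C@H](CO)[C@@H](O)[C@H]1O` carries a 1-benzofuran-2-yl group there. In a functional assay on CEM-DNR-bulk cells (Homo sapiens), read by MTT assay, with a stated time of 72 h (a higher number here means a weaker inhibitor, a lower number a stronger inhibitor), compound 1 gives > 20000 nM, which is a limit of the assay rather than a measured number. Compound 2 `Nc1nc2c(c(-c3cccs3)cn2[C@@H]2O[C@H](CO)[C@@H](O)[C@H]2O)c(=O)[nH]1` gives > 20000 nM in this assay, again a limit. Compound 3 `CNc1ncnc2c1c(I)cn2[C@@H]1O[C@H](CO)[C@@H](O)[C@H]1O` gives > 20000 nM in this assay, once more a limit. Compound 1 therefore stands nowhere in particular among the numbers shown, since every value sits at the same limit (the limit of > 20000 nM in this assay, at which 3 of the 3 values shown sit).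

Compound 4 `Cc1ncnc2c1c(-c1ccsc1)cn2[C@@H]1O[C@H](CO)[C@@H](O)[C@H]1O` has not yet been measured. It differs from compound 1 in one place: thiophen-3-yl in place of 1-benzofuran-2-yl on an aromatic carbon. Among the measured compounds shown here, no step between two measured compounds is available, so the size of this change cannot be read from a neighbouring pair. Because all three measured values sit at the limit (the limit of > 20000 nM in this assay, at which 3 of the 3 values shown sit), no change beyond the scatter in this assay is expected, and the most likely outcome is that compound 4 is again reported only as a limit. The step that the limit leaves unreadable from compound 1 to compound 4 is expected to be essentially flat. Compound 4 is thus estimated at 25000 nM in this assay, with a range from 8000 nM to 80000 nM.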

Compound 4, half-maximal inhibitory concentration: 8560 nM
Beside the measured number, compound 4's estimate is 2.9-fold (0.47 log units) above it; low and high end bracket the measured number.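

In this assay, putting thiophen-3-yl in place of 1-benzofuran-2-yl on this aromatic carbon gives an at least 2.3-fold lower number from compound 1 to compound 4 (0.36 log units; beyond the scatter). Among the compounds shown here, this is the first sign that the group at this position can move the read-out, since compound 4, at 8560 nM, gives an actual number that can be compared with later results. The true size of the step remains unknown, as the starting point is only a limit, and compound 4 is the only compound shown that has left that limit: the limit of > 20000 nM in this assay, at which 3 of the 4 values shown sit.

The change also swaps several features at once: the six-membered aromatic ring of carbon is lost, the heavy-atom count of the group falls, oxygen gives way to sulfur, and the point of attachment on the five-membered ring differs. Which of these matters stays open, and a furan-3-yl or a 1-benzothiophen-2-yl group on the same carbon, with the rest of compound 4 kept, would begin to separate them.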